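The source may hold more compounds than are shown below. What is called first, only, known or untested is meant among the compounds shown, and "the series" means these compounds.

Working notes on the amide series. In a functional assay on HCC1937 cells (Homo sapiens) for antiproliferative activity, read by CCK-8 assay, with a stated time of 72 h (a lower number here means a stronger inhibitor, a higher number a weaker inhibitor), compound 1 `COc1cccc(C(=O)Nc2cccc(-c3oc4cc(-c5ccc(F)cc5)ccc4c(=O)c3O)c2)c1` gives 18900 nM. In the same assay compound 2 `CCc1ccc(C(=O)Nc2cccc(-c3oc4cc(-c5ccc(F)cc5)ccc4c(=O)c3O)c2)cc1` gives 13200 nM, and compound 3 `O=C(Nc1cccc(-c2oc3cc(-c4ccc(F)cc4)ccc3c(=O)c2O)c1)c1ccc(Cl)nc1` gives 7550 nM. Compound 3 holds the lowest of the three numbers: its gap to compound 2 is within the scatter, its gap to compound 1 is beyond it. Every change measured so far sits on the carbonyl carbon and swaps one aryl for another: a 1.4-fold lower number from compound 1 to compound 2 (0.16 log units; within the scatter), a 2.5-fold lower number from compound 1 to compound 3 (0.40 log units; beyond the scatter), a 1.7-fold lower number from compound 2 to compound 3 (0.24 log units; within the scatter).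

Compound 4 `O=C(Nc1cccc(-c2oc3cc(-c4ccc(F)cc4)ccc3c(=O)c2O)c1)c1ccc([N+](=O)[O-])cc1` differs from compound 3 in that same place: 4-nitrophenyl in place of 6-chloropyridin-3-yl on a carbonyl carbon. All three measured steps bear on this, and none of them moved the number by more than a modest amount, with only one beyond the scatter. A step of similar size is therefore expected in this assay, without a firm direction, and most likely within the scatter.

Compound 4 is estimated at 9000 nM, with an expected range of 4000 nM to 20000 nM. This estimate corresponds to an expected step of a 1.2-fold higher number from compound 3 to compound 4 (0.08 log units; within the scatter).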

Compound 4, half-maximal inhibitory concentration: 5640 nM
For compound 4 the middle estimate is 1.6-fold (0.20 log units) above the measured one, within the range that was stated.
By their numbers in this assay, from the lowest: compounds 4, 3, 2 and 1 (each within the scatter of the next, the first and the last beyond it).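

In this assay, 4-nitrophenyl in place of 6-chloropyridin-3-yl on the carbonyl carbon gives a 1.3-fold lower number from compound 3 to compound 4 (0.13 log units; within the scatter) and so does not separate the two groups, even though one ring is carbon only and the other holds a nitrogen and carries a chlorine. Against the other two aryl groups the 4-nitrophenyl amide separates more clearly, with a 2.3-fold lower number from compound 2 to compound 4 (0.37 log units; beyond the scatter) for nitro in place of ethyl and a 3.4-fold lower number from compound 1 to compound 4 (0.53 log units; beyond the scatter) for 4-nitrophenyl in place of 3-methoxyphenyl, both modest steps though beyond the scatter. Nothing measured here accounts for these differences.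

From the compounds shown here alone, all four compounds carry an aryl group on the carbonyl carbon, so it remains open how a piperidine ring or a simple alkyl chain would behave there. Also open, going by these compounds, is whether an amine or a carboxylic acid in place of the nitro would keep the number of compound 4.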